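This account rests on a few compounds, and the source may have more. Where it says the series, first, only, none or still open, it means among the compounds named here.

The series shares one fused core, shown for compound 1 as `CCc1nnc(O)n2c(C(C)CC)nc(C)c12` and for compound 2 as `CCCc1nnc(O)n2c(CCC)nc(C)c12`, and both carry a hydroxy group. In a functional assay for inhibition, with Homo sapiens as the target (on this read-out lower numbers stand for stronger inhibition and higher numbers for weaker inhibition), compound 1 gives 45000 nM. In this assay compound 2 gives 16000 nM. Compound 3, `CCCc1nc(C)c2c(CC)nnc(S)n12`, carries a sulfanyl group instead. For compound 3 this assay reports only a limit, > 48000 nM, so its place among the numbers is open: it may sit anywhere at or beyond that limit, as stated in the limit of > 48000 nM in this assay, at which 1 of the 3 values shown sits. Compound 4, `CCCc1nc(C)c2c(CC)nnc(O)n12`, is the hydroxy counterpart of compound 3; the change is hydroxy in place of sulfanyl on an aromatic carbon. Among the compounds with values here, since the two hydroxy compounds measured so far give numbers rather than limits, compound 4 is expected to move toward stronger inhibition, with an expected step of an at least 1.6-fold lower number from compound 3 to compound 4 (0.20 log units; that floor lies within the scatter). Compound 4 is therefore estimated at 30000 nM in this assay, within a range from 10000 nM to 90000 nM, though a limit remains possible.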

Compound 4, half-maximal inhibitory concentration: 15600 nM
Beside the measured number, compound 4's estimate is 1.9-fold (0.28 log units) above it; low and high end bracket the measured number.
By their numbers in this assay, from the lowest: compounds 4 and 2 (each within the scatter of the next); then compound 1. At a limit, above all of these: compound 3.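

In this assay, hydroxy in place of sulfanyl on an aromatic carbon between two ring nitrogen atoms brings an at least 3.0-fold lower number from compound 3 to compound 4 (0.48 log units; beyond the scatter), the first step read at this position, and it is only a floor because compound 3 holds a limit and not a number: the limit of > 48000 nM in this assay, at which 1 of the 4 values shown sits.

On the chain side, hydrogen in place of methyl on a saturated chain carbon, two bonds along the chain from an aromatic carbon, gives a 1.0-fold lower number from compound 2 to compound 4 (0.01 log units; within the scatter), so compound 2 and compound 4 cannot be told apart. Hydrogen in place of methyl on a saturated chain carbon bound to an aromatic carbon and a saturated chain carbon gives a 2.9-fold lower number from compound 1 to compound 4 (0.46 log units; beyond the scatter), a step that does stand out from the scatter.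

On these data alone, the full size of the sulfanyl-to-hydroxy step stays open, as does what an amine or a methoxy group would do on that aromatic carbon. So does the effect of a longer chain in place of the ethyl or propyl groups.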